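The source may report more compounds than this note shows. Statements on the series, on what has been measured and on what is new or still open speak of the compounds shown alone.

Compound 1 (`CCOc1cccc2cc(-c3ccccc3)c(=O)oc12`) is the point of departure. Going by the values given here, in an assay on CHO cells for displacement of a labelled ligand from adenosine receptor A1 (Homo sapiens), read by radioligand binding (a higher number here means a weaker inhibitor, a lower number a stronger inhibitor), compound 1 gives 22100 nM, the only outright number in this small set. Compound 2 (`CCOc1cccc2cc(-c3ccc(Br)cc3)c(=O)oc12`) returns > 100000 nM in this assay, which is a limit of the assay rather than a number. The step of an at least 4.5-fold higher number from compound 1 to compound 2 (0.65 log units; beyond the scatter) therefore reads as a loss of binding, and compound 2 sits at the limit of > 100000 nM in this assay, at which 1 of the 2 values shown sits.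

Compound 3 (`CC(=O)Oc1cccc2cc(-c3ccccc3)c(=O)oc12`) carries a different change: acetyl in place of ethyl on an oxygen on an aromatic ring, which read one bond further out is ethoxy to acetoxy. Among the compounds with values here, no measured step touches this position; the only step measured so far exchanges hydrogen for bromo on the phenyl ring and says nothing about the oxygen bearing the ethyl group. Within the data shown here, with no precedent to lean on, the expected step of a 1.1-fold higher number from compound 1 to compound 3 (0.05 log units; within the scatter) in this assay is taken as none beyond the scatter, with a wide band of uncertainty. Compound 3 is accordingly estimated at 25000 nM, between 7000 nM and 90000 nM.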

Compound 3, inhibition constant: 6930 nM
Compound 3: middle estimate off by 3.6-fold (0.56 log units), on the high side; the whole stated range lies above it.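

The oxygen on the aromatic ring proves to be a place where the choice of group changes the reading in this assay: acetyl in place of ethyl gives a 3.2-fold lower number from compound 1 to compound 3 (0.50 log units; beyond the scatter). Going by these compounds alone, this is the first change in the set to move toward stronger binding, whereas the only earlier step, bromo in place of hydrogen on the phenyl ring, went the other way with an at least 4.5-fold higher number from compound 1 to compound 2 (0.65 log units; beyond the scatter). The two groups have the same carbon count and differ by the carbonyl oxygen, counted as one added hydrogen-bond acceptor, but nothing in the data shown accounts for the gain.

Going by these compounds, with only ethyl and acetyl on this oxygen, it remains open whether the gain belongs to the carbonyl itself or to the acetyl group as a whole, and what a free hydroxyl, a longer acyl chain such as butanoyl, or a carbamate carrying an amine would do in the same place. Also open, on these data alone, is whether bromo on the phenyl ring would cost as much binding with acetyl on the oxygen as it does with ethyl there.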